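The source may report more compounds than this note shows. Statements on the series, on what has been measured and on what is new or still open speak of the compounds shown alone.

Series notes, carbamate variation on the shared core.

Of the compounds shown here, three have been measured in an assay for inhibition of serine/threonine-protein kinase PAK 4 (Homo sapiens), read by FRET and Z'-LYTE, with a stated time of 60 min, tested at 5 uM, in the presence of a further agent that is not named here; on this read-out higher numbers stand for a stronger effect at the one concentration tested and lower numbers for a weaker effect. Compound 1 `C[C@@H]1CN(C(=O)c2nc(Nc3cc(C4CC4)[nH]n3)c3cc(Cl)ccc3n2)CCN1C(=O)OC(C)(C)C` gives 22.7%. Compound 2 `CC(OC(=O)C(C)C)OC(=O)N1CCN(C(=O)c2nc(Nc3cc(C4CC4)[nH]n3)c3cc(Cl)ccc3n2)C[C@H]1C` gives 25.8%. Compound 3 `C[C@@H]1CN(C(=O)c2nc(Nc3cc(C4CC4)[nH]n3)c3cc(Cl)ccc3n2)CCN1C(=O)OCC(Cl)(Cl)Cl` gives 63%. Compound 2 thus stands second highest of the three numbers; its nearest neighbour is compound 1, as the step of a number 3.1 percentage points higher from compound 1 to compound 2 (within the scatter) shows, while compound 3 lies far above it, as the step of a number 37.2 percentage points higher from compound 2 to compound 3 (beyond the scatter) shows. The other step, a number 40.3 percentage points higher from compound 1 to compound 3 (beyond the scatter), also comes from the 2,2,2-trichloroethyl replacement.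

Compound 4 `C[C@@H]1CN(C(=O)c2nc(Nc3cc(C4CC4)[nH]n3)c3cc(Cl)ccc3n2)CCN1C(=O)OCOC(=O)C(C)(C)C` is not yet measured in this assay. It differs from compound 2 in one place: (((tert-butyl)carbonyl)oxy)methyl in place of 1-((isopropylcarbonyl)oxy)ethyl on an oxygen next to a carbonyl group. The two have the same atoms joined differently, both carrying an acyloxyalkyl group on an oxygen next to a carbonyl group.

The step that bears most directly on this change is a number 3.1 percentage points higher from compound 1 to compound 2 (within the scatter), which swapped tert-butyl for 1-((isopropylcarbonyl)oxy)ethyl and stayed within the scatter. The large steps to compound 3 involve 2,2,2-trichloroethyl and do not apply here. Compound 4 is therefore expected to show no step beyond the scatter, that is a number 0.8 percentage points lower from compound 2 to compound 4 (within the scatter). For compound 4 the estimated value in this assay is 25%, with a range from 10% to 45%.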

Compound 4, a percentage reported as inhibition, at one concentration (the size of the read-out at that concentration, not a potency): 24.1%
Beside the measured number, compound 4's estimate is 0.9 percentage points above it; the measured number falls inside the stated range.
By their numbers in this assay, from the lowest: compounds 1, 4 and 2 (each within the scatter of the next); then compound 3.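

In this assay, exchanging 1-((isopropylcarbonyl)oxy)ethyl for (((tert-butyl)carbonyl)oxy)methyl on an oxygen next to a carbonyl group gives a number 1.7 percentage points lower from compound 2 to compound 4 (within the scatter), so these two acyloxyalkyl groups, with the same atoms joined differently, cannot be told apart at this position. A second acyloxyalkyl group now also matches tert-butyl, with a number 1.4 percentage points higher from compound 1 to compound 4 (within the scatter), which places compound 1, compound 2 and compound 4 on one level within the scatter. The step of a number 38.9 percentage points lower from compound 3 to compound 4 (beyond the scatter), with ((tert-butyl)carbonyl)oxy in place of trichloromethyl on a saturated chain carbon bound to an oxygen next to a carbonyl group, leaves compound 3 alone above the other three, each of its steps to them being large and beyond the scatter.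

No available evidence accounts for this single level or for the separate standing of compound 3. Open, going by these compounds, is whether 2,2,2-trifluoroethyl, 2-chloroethyl or a plain ethyl chain on this oxygen would stand with compound 3 or with the other three, so the trichloroethyl result remains a single point.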